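Nitro for Amino on the Benzamide of Compound 2

The source may report more compounds than this note shows. Statements on the series, on what has been measured and on what is new or still open speak of the compounds shown alone.

Measured so far in a functional assay on NCI-H460 cells (Homo sapiens) for cytotoxicity, read by MTT assay; on this read-out higher numbers stand for weaker inhibition and lower numbers for stronger inhibition:
- compound 1, `CCCOC(=O)Nc1ccc(S(=O)(=O)N2C[C@H](c3ccccc3)NC2=O)cc1CC`: 60 nM
- compound 2, `CCc1cc(S(=O)(=O)N2C[C@H](c3ccccc3)NC2=O)ccc1NC(=O)c1ccc(N)cc1`: 670 nM
- compound 3, `CCOC(=O)Nc1ccc(S(=O)(=O)N2C(=O)N[C@@H](c3ccccc3)C2C)cc1Cl`: 6000 nM

Compound 2 stands second highest of the three numbers, between compound 1 and compound 3, with both gaps beyond the scatter. Compound 4, `CCc1cc(S(=O)(=O)N2C[C@H](c3ccccc3)NC2=O)ccc1NC(=O)c1ccc([N+](=O)[O-])cc1`, differs from compound 2 by nitro in place of amino on an aromatic carbon, so the 4-aminophenyl becomes a 4-nitrophenyl. Among the measured compounds shown here, the only measured step, an 11-fold higher number from compound 1 to compound 2 (1.05 log units; beyond the scatter), exchanges propoxy for the whole 4-aminophenyl and does not probe the amino itself; no measured pair isolates this change. For the measured compounds named here, with no bearing step, compound 4 is expected to stay within the scatter of compound 2, an expected step of a 1.1-fold lower number from compound 2 to compound 4 (0.05 log units; within the scatter). The estimate for compound 4 is 600 nM, ranging from 200 nM to 2000 nM.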

Compound 4, half-maximal inhibitory concentration: 800 nM
Beside the measured number, compound 4's estimate is 1.3-fold (0.12 log units) below it; the measured number falls inside the stated range.
By their numbers in this assay, from the lowest: compound 1; then compounds 2 and 4 (each within the scatter of the next); then compound 3.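

In this assay, nitro in place of amino on this aromatic carbon gives a 1.2-fold higher number from compound 2 to compound 4 (0.08 log units; within the scatter), so the two groups read alike at this position. The 4-nitrophenyl also gives a 13-fold higher number from compound 1 to compound 4 (1.12 log units; beyond the scatter), which shows that the large step away from propoxy on the carbonyl carbon does not depend on the amino. No available evidence explains why amino and nitro read alike here. Going by these compounds, whether a methoxy or a carboxylic acid on the same aromatic carbon would also stay within the scatter remains open, as does the effect of a butoxy in place of propoxy.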